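This account rests on a few compounds, and the source may have more. Where it says the series, first, only, none or still open, it means among the compounds named here.

Compound 1, `O=C(O)[C@H]1NC[C@@H](O)[C@H](O)[C@H]1O`: 4.2%
Compound 2, `O=C(O)[C@H]1NC[C@H](O)[C@H](O)[C@@H]1O`: 4.5%
Compound 3, `O=C(O)[C@H]1NC[C@@H](O)[C@@H](O)[C@@H]1O`: 3.8%

All three compounds are stereoisomers of one another, sharing the same atoms and bonds. In an assay for inhibition of alpha-N-acetylgalactosaminidase (Gallus gallus), tested at 1000 uM (on this read-out higher numbers stand for more inhibition at the one concentration tested (going by the name of the read-out) and lower numbers for less inhibition), compound 3 gives 3.8%, the lowest of the three numbers, though its nearest neighbour compound 1 gives 4.2% and compound 2 gives 4.5%, so that none of the three stands apart from the others. The steps among them are a number 0.3 percentage points higher from compound 1 to compound 2 (within the scatter), a number 0.4 percentage points lower from compound 1 to compound 3 (within the scatter) and a number 0.7 percentage points lower from compound 2 to compound 3 (within the scatter), each of which is a change of configuration only (the fact that compounds 1 and 2 differ only in the configuration as drawn, (the fact that compounds 1 and 3 differ only in the configuration as drawn), (the fact that compounds 2 and 3 differ only in the configuration as drawn)), and none moves the read-out beyond the scatter.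

Compound 4, `O=C(O)[C@H]1NC[C@H](O)[C@@H](O)[C@H]1O`, is the next isomer in this series. Relative to compound 3 the change is the two compounds have the same atoms and bonds and differ only in configuration as drawn: 2 of 4 stereo elements differ; a stereocentre at a saturated ring carbon is drawn R in compound 3 and S in compound 4; a stereocentre at a saturated ring carbon is drawn R in compound 3 and S in compound 4. The three measured steps all bear on this kind of change, and all were small; a step of the same kind is therefore expected to be a number 0.7 percentage points higher from compound 3 to compound 4 (within the scatter), that is, no change beyond the scatter in this assay. Compound 4 is expected to give 4.5%, within a range from 0% to 14%.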

Compound 4, a percentage reported as inhibition, at one concentration (the size of the read-out at that concentration, not a potency): 31%
For compound 4 the middle estimate is 26.5 percentage points below the measured one, outside the stated range (above it).
By their numbers in this assay, from the lowest: compounds 3, 1 and 2 (each within the scatter of the next); then compound 4.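

In this assay, compound 4 separates from all three of its isomers, with a number 27.2 percentage points higher from compound 3 to compound 4 (beyond the scatter), a number 26.5 percentage points higher from compound 2 to compound 4 (beyond the scatter) and a number 26.8 percentage points higher from compound 1 to compound 4 (beyond the scatter), so its number is the highest of the four at the one concentration tested. Among the compounds shown here, the earlier compounds showed only that a change of two stereo elements could leave the read-out where it was; these steps show that a change of the same size can also move it beyond the scatter, so the count of differing stereo elements does not decide the outcome, and the particular arrangement in compound 4 stands apart from those in compounds 1, 2 and 3. No atom or bond changes in the step to compound 4, so the shift rests on configuration alone: the fact that compounds 3 and 4 differ only in the configuration as drawn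

The compounds shown leave open whether one of the two changed stereocentres would carry this gain by itself or whether both are required. They also leave open whether the inhibition seen with compound 4 would persist if a hydroxymethyl group or a methyl ester stood in place of the carboxylic acid.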